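Adding iodine to the anilino ring of compound 3

A few compounds are considered here, and "the series" means these few. Any claim that something is new, unique, unknown or untested is made for them only; others in the source may bear on it.

Of the compounds shown here, three built on one shared core have been measured in a functional assay on NCI-H1299 cells (Homo sapiens) for antiproliferative activity, read by MTT assay, with a stated time of 72 h; on this read-out higher numbers stand for weaker inhibition and lower numbers for stronger inhibition. Compound 1 `CCOC1=C(C(=O)c2ccccc2)C(c2ccc(Br)cc2)N(CCCn2ccnc2)C1=O` gives 28900 nM. Compound 2 `O=C(C1=C(OC2CCCCC2)C(=O)N(CCCn2ccnc2)C1c1ccc(Br)cc1)c1ccccc1` gives 19900 nM in this assay. Compound 3 `O=C(C1=C(Nc2ccccc2)C(=O)N(CCCn2ccnc2)C1c1ccc(Br)cc1)c1ccccc1` gives 21200 nM in this assay. Every measured step between them is small: a 1.5-fold lower number from compound 1 to compound 2 (0.16 log units; within the scatter), a 1.4-fold lower number from compound 1 to compound 3 (0.13 log units; within the scatter), and a 1.1-fold higher number from compound 2 to compound 3 (0.03 log units; within the scatter). Compound 3 stands second highest of the three numbers, with compound 2 nearest and compound 1 furthest, and all three lie within the scatter of one another.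

Compound 4 `O=C(C1=C(Nc2ccc(I)cc2)C(=O)N(CCCn2ccnc2)C1c1ccc(Br)cc1)c1ccccc1` differs from compound 3 in one place: iodo in place of hydrogen on an aromatic carbon. Put another way, the anilino group becomes a (4-iodophenyl)amino group, the iodo sitting on an aromatic carbon of a six-membered aromatic ring of carbon only, para to a large group. None of the three measured steps touches a substituent on that ring; each exchanges the whole group on the double-bonded ring carbon, and each stayed within the scatter. For the measured compounds named here, no measured step bears directly on adding an iodo at this place. With nothing pointing either way, the step from compound 3 to compound 4 in this assay is expected to be small: a 1.2-fold lower number from compound 3 to compound 4 (0.07 log units; within the scatter). Compound 4 is estimated at 18000 nM, with a range from 6000 nM to 50000 nM.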

Compound 4, half-maximal inhibitory concentration: 19400 nM
The estimate for compound 4 lay 1.1-fold (0.03 log units) below the measured number, and the stated range covers the measured number.
By their numbers in this assay, from the lowest: compounds 4, 2, 3 and 1 (each within the scatter of the next).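

In this assay, the one change shown on the anilino ring itself, an iodo on an aromatic carbon para to a large group, gives a 1.1-fold lower number from compound 3 to compound 4 (0.04 log units; within the scatter) and so stays within the usual scatter despite adding a single heavy iodine atom. The larger exchanges read the same way, with a 1.0-fold lower number from compound 2 to compound 4 (0.01 log units; within the scatter) for (4-iodophenyl)amino in place of cyclohexyloxy and a 1.5-fold lower number from compound 1 to compound 4 (0.17 log units; within the scatter) for (4-iodophenyl)amino in place of ethoxy, so four different groups on the double-bonded ring carbon now lie within the scatter of one another. No measurement accompanies these numbers that could explain this result.

Still open, as far as these compounds go, is whether a group other than iodo on the same ring, such as a methoxy, an amine or a carboxylic acid, or an iodo at another place on that ring, would give a step beyond the scatter. Also open, from the compounds shown here alone, is whether a change elsewhere on the shared core, such as a longer chain in place of the propyl link, would move the number any further than these changes have.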